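Removing a Chain Methyl in Two Related Amides

This account rests on a few compounds, and the source may have more. Where it says the series, first, only, none or still open, it means among the compounds named here.

Compound 1 `CCC(C)C(C(=O)Nc1ccc(C(C)=O)cc1)N(C(=O)c1ccccc1)S(=O)(=O)c1ccc(C)cc1` gives 41.1% in a functional assay for inhibition, read by spectrophotometry, with a stated time of 20 min, tested at 4 mg/mL; on this read-out higher numbers stand for a stronger effect at the one concentration tested and lower numbers for a weaker effect. Compound 2 `CC(=O)c1ccc(NC(=O)C(C(C)C)N(C(=O)c2ccccc2)S(=O)(=O)c2ccc(C)cc2)cc1` shares its core but carries hydrogen in place of methyl on a saturated chain carbon, three bonds along the chain from an amide-type nitrogen and a carbonyl carbon; in this assay compound 2 gives 36.6%, a step of a number 4.5 percentage points lower from compound 1 to compound 2 (within the scatter). Compound 3 `CCC(C)C(C(=O)Nc1ccc(C(C)=O)cc1)N(C(=O)c1ccccc1)S(=O)(=O)c1ccccc1` differs from compound 1 by hydrogen in place of methyl on an aromatic carbon, and in this assay compound 3 gives 15.5%, a step of a number 25.6 percentage points lower from compound 1 to compound 3 (beyond the scatter). Compound 4 `CC(=O)c1ccc(NC(=O)C(C(C)C)N(C(=O)c2ccccc2)S(=O)(=O)c2ccccc2)cc1` has not been measured; it differs from compound 3 by hydrogen in place of methyl on a saturated chain carbon, three bonds along the chain from an amide-type nitrogen and a carbonyl carbon, the same change that was made from compound 1 to compound 2. Because the earlier step measured a number 4.5 percentage points lower from compound 1 to compound 2 (within the scatter) lies within the scatter, the expected step for compound 4 is a number 4.5 percentage points lower from compound 3 to compound 4 (within the scatter). The estimate for compound 4 in this assay is 11%, expected to fall between 0% and 25%.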

Compound 4, a percentage reported as inhibition, at one concentration (the size of the read-out at that concentration, not a potency): 52.2%
The estimate for compound 4 lay 41.2 percentage points below the measured number; the whole stated range lies below it.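

On the core without the aromatic methyl, going from sec-butyl to isopropyl gives a number 36.7 percentage points higher from compound 3 to compound 4 (beyond the scatter), so the result of this change does not carry over from one core to the other: the same change on two cores in this assay, a number 4.5 percentage points lower (within the scatter) from compound 1 to compound 2 and a number 36.7 percentage points higher (beyond the scatter) from compound 3 to compound 4, 41.2 percentage points apart, beyond the scatter of two such steps

Removing the aromatic methyl likewise depends on the chain, giving a number 15.6 percentage points higher from compound 2 to compound 4 (beyond the scatter) with isopropyl in place, and its result differs from that with sec-butyl: the same change on two cores in this assay, a number 25.6 percentage points lower (beyond the scatter) from compound 1 to compound 3 and a number 15.6 percentage points higher (beyond the scatter) from compound 2 to compound 4, 41.2 percentage points apart, beyond the scatter of two such steps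

These four compounds show that the two changes cannot be treated as independent here, but they do not show why, nor whether this holds beyond this set.

Still open, from the compounds shown here alone, is how a longer chain or an amine at the chain position would behave. Also open, going by these compounds, is whether a chlorine in place of the aromatic methyl would show the same dependence on the chain.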